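Notes on the piperidine substituent in this series

The source may hold more compounds than are shown below. What is called first, only, known or untested is meant among the compounds shown, and "the series" means these compounds.

Compound 3 `Cc1cccc2c1nc(COc1ccc(Cl)cc1)n2CCCC1CCN(CC(=O)O)CC1` gives 2190 nM in an assay on AV12 cells for binding affinity to Neuropeptide Y receptor type 1 (Homo sapiens) (a higher number here means a weaker inhibitor, a lower number a stronger inhibitor), the highest number among the three measured compounds. Compound 1 `Cc1cccc2c1nc(COc1ccc(Cl)cc1)n2CCCC1CCNCC1` gives 335 nM, and compound 2 `CCCN1CCC(CCCn2c(COc3ccc(Cl)cc3)nc3c(C)cccc32)CC1` gives 29 nM. The steps to compound 3 were a 6.5-fold higher number from compound 1 to compound 3 (0.82 log units; beyond the scatter) and a 76-fold higher number from compound 2 to compound 3 (1.88 log units; beyond the scatter); the step between the two stronger binders was a 12-fold lower number from compound 1 to compound 2 (1.06 log units; beyond the scatter).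

Compound 4 `Cc1cccc2c1nc(COc1ccc(Cl)cc1)n2CCCC1CCN(CC(=O)N2CCCCC2)CC1` differs from compound 3 in one place: piperidin-1-yl in place of hydroxy on a carbonyl carbon, so the carboxy becomes a (piperidin-1-yl)carbonyl and the carboxymethyl becomes a ((piperidin-1-yl)carbonyl)methyl. Among the compounds with values here, no measured step covers exactly this change. The bearing steps are those that introduced the carboxy: compound 3 stands beyond the scatter above compound 1 with the carboxymethyl on the ring nitrogen, and further above compound 2. Within the data shown here, removing the hydroxy from that carboxy and replacing it with a ring is therefore expected to move the number back downward, with the size uncertain since the entering piperidin-1-yl has no precedent among the measured compounds. For compound 4 the expected step is a 12-fold lower number from compound 3 to compound 4 (1.09 log units; beyond the scatter). Compound 4 is estimated at 180 nM in this assay, within a range of 35 nM to 900 nM.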

Compound 4, inhibition constant: 136 nM
For compound 4 the middle estimate is 1.3-fold (0.12 log units) above the measured one, within the range that was stated.
By their numbers in this assay, from the lowest: compound 2; then compound 4; then compound 1; then compound 3.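

In this assay, the exchange of hydroxy for piperidin-1-yl on the carbonyl carbon gives a 16-fold lower number from compound 3 to compound 4 (1.21 log units; beyond the scatter), so the weak binding of compound 3 goes with the carboxy and not with any carbonyl-bearing chain on the amine nitrogen in a ring. The ((piperidin-1-yl)carbonyl)methyl group also improves on hydrogen at that nitrogen, with a 2.5-fold lower number from compound 1 to compound 4 (0.39 log units; beyond the scatter), which makes it the second substituent here to do so, although it stays short of propyl, with a 4.7-fold higher number from compound 2 to compound 4 (0.67 log units; beyond the scatter). No measurement shown here gives a reason for these differences.

The compounds shown leave open whether the recovery needs the entering ring or only the loss of hydroxy, a question that a primary amide or a methyl ester on the same carbonyl carbon would help to separate. They also leave open what the carbonyl itself contributes, which a 2-(piperidin-1-yl)ethyl chain on the amine nitrogen could test, and whether a butyl chain would go beyond propyl.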